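From bromo to hydroxy in the series

The compounds below may be only part of what the source reports. "The series", "measured", "known", "first", "only" and "open" are said of these compounds alone.

In a functional assay on HeLa cells (Homo sapiens) for inhibition, read by colorimetric assay, with a stated time of 3 days (on this read-out lower numbers stand for stronger inhibition and higher numbers for weaker inhibition), compound 2 (`O=C(CCCCCCNC(=O)C(O)(O)C(F)(F)F)Nc1ncc(-c2ccc(Br)cc2)s1`) gives 1220 nM and stands within the scatter of both other measured compounds: compound 1 (`COc1ccc(-c2cnc(NC(=O)CCCCCCNC(=O)C(O)(O)C(F)(F)F)s2)cc1`) at 1600 nM and compound 3 (`COc1ccc2sc(NC(=O)CCCCCCNC(=O)C(O)(O)C(F)(F)F)nc2c1`) at 1860 nM on a different core. The three values therefore set no order.

Compound 4 (`O=C(CCCCCCNC(=O)C(O)(O)C(F)(F)F)Nc1ncc(-c2ccc(O)cc2)s1`) keeps everything in compound 2 except one group: hydroxy in place of bromo on an aromatic carbon and so reads as 4-bromophenyl to 4-hydroxyphenyl, with hydroxy in place of bromo on an aromatic carbon, para to a large group.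

Among the compounds with values here, the one measured exchange at this place is a 1.3-fold lower number from compound 1 to compound 2 (0.12 log units; within the scatter) and it is the only guide available. Within the data shown here, no measured compound carries a hydroxy, so the data give no direct reading of this group. On the size of that single step, no change beyond the scatter is expected for compound 4 in this assay and no direction can be argued. The expected step is a 1.2-fold higher number from compound 2 to compound 4 (0.09 log units; within the scatter) and it remains an estimate resting on one comparison. For compound 4 the estimated value is 1500 nM with an expected range from 750 nM to 3000 nM in this read-out.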

Compound 4, half-maximal inhibitory concentration: 6380 nM
Estimate against measurement, compound 4: 4.3-fold (0.63 log units) below; measured number outside the range, above it.
By their numbers in this assay, from the lowest: compounds 2, 1 and 3 (each within the scatter of the next); then compound 4.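

In this assay the place para to a large group turns out not to be indifferent to its substituent: a 5.2-fold higher number from compound 2 to compound 4 (0.72 log units; beyond the scatter) comes with hydroxy in place of bromo, and a 4.0-fold higher number from compound 1 to compound 4 (0.60 log units; beyond the scatter) comes with hydrogen in place of methyl on the oxygen. Within the data shown here, the earlier exchange of methoxy for bromo, a 1.3-fold lower number from compound 1 to compound 2 (0.12 log units; within the scatter) gave no separation, so compound 4 is the first compound on this core to stand apart, with the higher number and thus weaker inhibition than both compound 1 and compound 2. The data offer no measurement that could account for this shift.

Still open, as far as these compounds go, is how an amine, a carboxylic acid or a fluoro at this same place would read in this assay and whether any of them would stay with compound 1 and compound 2 or move towards compound 4. From the compounds shown here alone, with a single hydroxy compound on a single core, it also remains unknown whether the same exchange would carry over to the core of compound 3, which holds a methoxy of its own.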